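Swapping a Ring at the End of the Chain

The source may report more compounds than this note shows. Statements on the series, on what has been measured and on what is new or still open speak of the compounds shown alone.

Of the compounds shown here, two sharing one core have been tested in a functional assay on KB cells (Homo sapiens) for cytotoxicity; a higher number here means that more compound is needed for the effect, a lower number that less compound is needed. Compound 1, `COC1=C(C)C(=O)/C(=C(O)/C=C/c2cccc(OC)c2)C(=O)C1(C)C`, gives 3.3 ug/mL. Compound 2, `COC1=C(C)C(=O)/C(=C(O)/C=C/c2ccc(C)cc2)C(=O)C1(C)C`, gives 3.9 ug/mL. Among the compounds with values here, the only measured step, a 1.2-fold higher number from compound 1 to compound 2 (0.07 log units; within the scatter), leaves the two numbers within the usual scatter of each other, so compound 2 cannot be set apart from compound 1 on this evidence; its number is simply one of two that agree.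

Compound 3, `COC1=C(C)C(=O)/C(=C(O)/C=C/c2nccs2)C(=O)C1(C)C`, has not yet been measured. Its change from compound 2 is 1,3-thiazol-2-yl in place of 4-methylphenyl on a double-bonded chain carbon bound to a double-bonded chain carbon. Within the data shown here, the one measured step exchanged a substituted six-membered carbon ring for another of the same kind and produced no shift beyond scatter; the present change instead brings in a smaller ring with two hetero atoms, for which no measured step exists. Among the measured compounds shown here, the expectation therefore rests on the single step from compound 1 to compound 2, which was flat, and the broader uncertainty of an unmatched change.

Compound 3 is expected to give about 5 ug/mL, within a range from 2 ug/mL to 12 ug/mL. The expected step, a 1.3-fold higher number from compound 2 to compound 3 (0.11 log units; within the scatter), is modest and may not exceed the scatter.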

Compound 3, concentration for half-maximal effect: 4.3 ug/mL
Beside the measured number, compound 3's estimate is 1.2-fold (0.07 log units) above it; the measured number falls inside the stated range.
By their numbers in this assay, from the lowest: compounds 1, 2 and 3 (each within the scatter of the next).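

With 1,3-thiazol-2-yl on the double-bonded chain carbon bound to a double-bonded chain carbon, this assay shows a 1.1-fold higher number from compound 2 to compound 3 (0.04 log units; within the scatter) and also a 1.3-fold higher number from compound 1 to compound 3 (0.11 log units; within the scatter). Both steps stay within the scatter, so this position now holds a five-membered aromatic ring with 2 hetero atoms, and the result cannot be told apart from those with the two six-membered carbon rings, even though the ring that enters has 5 heavy atoms where 4-methylphenyl has 7 and carries nitrogen and sulfur. No measurement at hand accounts for this agreement among the three compounds.

From the compounds shown here alone, all three groups at this position are aromatic rings, so it remains open whether the numbers would stay together with a dimethylamino group, a carboxylic acid or a plain alkyl chain in the same place. The shared core is also the same throughout, so these compounds say nothing about changes made there, and the flat picture at the ring end rests on this assay alone.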